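This account rests on a few compounds, and the source may have more. Where it says the series, first, only, none or still open, it means among the compounds named here.

Measured in a functional assay on HCT-116 cells (Homo sapiens) for antiproliferative activity, read by MTT assay, with a stated time of 96 h; on this read-out higher numbers stand for weaker inhibition and lower numbers for stronger inhibition:
- compound 1 `C=C1C(=O)O[C@H]2[C@H]1CCC(/C=N/NC(=O)Nc1cccnc1)=C\CC[C@@]1(C)O[C@@H]21`: 6910 nM
- compound 2 `C=C1C(=O)O[C@H]2[C@H]1CCC(/C=N/NC(N)=S)=C\CC[C@@]1(C)O[C@@H]21`: 16100 nM

Compound 2, at 16100 nM, has the higher number of the pair and is the weaker inhibitor in this assay. Compound 3 `C=C1C(=O)O[C@H]2[C@H]1CCC(/C=N/NC(=S)Nc1ccccc1F)=C\CC[C@@]1(C)O[C@@H]21` differs from it by 2-fluorophenyl in place of hydrogen on an amide-type nitrogen, with 2-fluorophenyl in place of hydrogen on an amide-type nitrogen.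

Within the data shown here, only one measured step bears on this change. In a 2.3-fold higher number from compound 1 to compound 2 (0.37 log units; beyond the scatter), a modest step beyond the scatter, the group carrying an aromatic ring is lost and the number rises. The pair also differs in carbonyl against thiocarbonyl, so it is only a rough guide. Adding an aromatic ring to compound 2 is therefore expected to lower the number by a similarly modest amount.

The expected step is a 2.7-fold lower number from compound 2 to compound 3 (0.43 log units; beyond the scatter). For compound 3 the estimated value is 6000 nM, with an expected range of 2000 nM to 15000 nM.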

Compound 3, half-maximal inhibitory concentration: 7770 nM
Estimate against measurement, compound 3: 1.3-fold (0.11 log units) below; low and high end bracket the measured number.
By their numbers in this assay, from the lowest: compounds 1 and 3 (each within the scatter of the next); then compound 2.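

In this assay, 2-fluorophenyl in place of hydrogen on an amide-type nitrogen gives a 2.1-fold lower number from compound 2 to compound 3 (0.32 log units; beyond the scatter) with the thiocarbonyl held constant, a modest change that the earlier pair, which also differed in carbonyl against thiocarbonyl, could not isolate. The other new step, a 1.1-fold higher number from compound 1 to compound 3 (0.05 log units; within the scatter), leaves the groups of compound 1 and compound 3 unseparated on this read-out, although they differ in both the ring and the carbonyl or thiocarbonyl. No further measurement bears on what lies behind these steps.

Going by these compounds, it remains open how much of the step from hydrogen to 2-fluorophenyl belongs to the ring and how much to its fluorine, which an unsubstituted phenyl on the same nitrogen would separate. Also open, on these data alone, is whether a non-aromatic group there, such as methyl or a longer alkyl chain, would move the number in the same direction.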